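A few compounds are considered here, and "the series" means these few. Any claim that something is new, unique, unknown or untested is made for them only; others in the source may bear on it.

Measured compounds:
- Compound 1 `CCCCC(=O)N(Cc1ccc(OC)c(O)c1)c1cc(OC)c(OC)c(OC)c1` gives 66 nM in a functional assay on MGC-803 cells (Homo sapiens) for inhibition, read by MTT assay, with a stated time of 48 h; on this read-out higher numbers stand for weaker inhibition and lower numbers for stronger inhibition.
- Compound 2 `COc1ccc(CNc2cc(OC)c(OC)c(OC)c2)cc1Br` gives 29400 nM in this assay.
- Compound 3 `COC(=O)c1cc(CNc2cc(OC)c(OC)c(OC)c2)ccc1OC` gives 49600 nM in this assay.

Compound 1 has the lowest number of the three, so it is the strongest inhibitor here; compound 2 and compound 3 lie far above it. For the measured compounds named here, the only single-change step among the measured compounds is a 1.7-fold higher number from compound 2 to compound 3 (0.23 log units; within the scatter), and it concerns a group on an aromatic ring, not the chain that is altered now. Compound 4 `COc1ccc(CN(C(=O)CCCl)c2cc(OC)c(OC)c(OC)c2)cc1O` differs from compound 1 by chloro in place of ethyl on a saturated chain carbon, two bonds along the chain from a carbonyl carbon, that is butylcarbonyl to (2-chloroethyl)carbonyl. Going by the values given here, no measured step touches this chain, so nothing in the data points to a direction of change. Compound 1 already sits at the low end of the numbers, and with no guide from the measured steps, compound 4 is expected to stay near it, with a step of a 1.5-fold higher number from compound 1 to compound 4 (0.18 log units; within the scatter) that is expected to fall within the scatter. The estimate for compound 4 in this assay is 100 nM, with a range from 30 nM to 400 nM.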

Compound 4, half-maximal inhibitory concentration: 140 nM
The estimate for compound 4 lay 1.4-fold (0.15 log units) below the measured number, and the stated range covers the measured number.
By their numbers in this assay, from the lowest: compound 1; then compound 4; then compounds 2 and 3 (each within the scatter of the next).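

For the compounds shown here, the chain of compound 1 is touched here for the first time, and the change gives a 2.1-fold higher number from compound 1 to compound 4 (0.33 log units; beyond the scatter) in this assay. This shows that the position does respond to what it carries, though only modestly: inhibition weakens when chloro replaces ethyl on this saturated chain carbon, two bonds along the chain from a carbonyl carbon, but it is far from lost. Why the number moves this way cannot be told, since nothing measured here bears on a cause.

A single step gives one direction for one pair, so it cannot show how an amine, a carboxylic acid or a longer chain at this place would fare. It also leaves open whether the step comes from the chlorine itself or from the loss of the ethyl carbons.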